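Swapping 3-amino-4-methoxyphenyl for 4-aminophenyl

The source may report more compounds than this note shows. Statements on the series, on what has been measured and on what is new or still open speak of the compounds shown alone.

Of the compounds shown here, two sharing one core have numbers so far. In a functional assay on MCF7 cells (Homo sapiens) for antiproliferative activity, read by MTT assay, with stated times of 24 h and 72 h (on this read-out higher numbers stand for weaker inhibition and lower numbers for stronger inhibition), compound 1 `COc1ccc([C@@H]2[C@H](Oc3ccccc3)C(=O)N2c2cc(OC)c(OC)c(OC)c2)c([N+](=O)[O-])c1O` gives 89000 nM, and compound 2 `COc1ccc([C@@H]2[C@H](Oc3ccccc3)C(=O)N2c2cc(OC)c(OC)c(OC)c2)cc1N` gives 12200 nM, the lower of the two and beyond the scatter of the other. Compound 3 `COc1cc(N2C(=O)[C@@H](Oc3ccccc3)[C@H]2c2ccc(N)cc2)cc(OC)c1OC` has yet to be measured. It carries 4-aminophenyl in place of 3-amino-4-methoxyphenyl on a saturated ring carbon of the four-membered non-aromatic ring with 1 nitrogen: 4-aminophenyl in place of 3-amino-4-methoxyphenyl on a saturated ring carbon.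

For the measured compounds named here, only one measured step bears on this place: a 7.3-fold lower number from compound 1 to compound 2 (0.86 log units; beyond the scatter). Going by the values given here, that modest step shows that this assay responds to a change of the group on this carbon, but it does not isolate the loss of the methoxy group, and no measured pair does. Its size therefore sets only a rough scale, and the direction is a tentative call. The expected result is a small move toward weaker inhibition, a 1.6-fold higher number from compound 2 to compound 3 (0.21 log units; within the scatter), which may not clear the scatter. For compound 3 the estimated value is 20000 nM, with an expected range of 6000 nM to 70000 nM.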

Compound 3, half-maximal inhibitory concentration: 160000 nM
Compound 3: the middle estimate sits 8.0-fold (0.90 log units) below what was measured, and the stated range ends below it.
By their numbers in this assay, from the lowest: compound 2; then compounds 1 and 3 (each within the scatter of the next).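

In this assay the exchange of 3-amino-4-methoxyphenyl for 4-aminophenyl on this saturated ring carbon gives a 13-fold higher number from compound 2 to compound 3 (1.12 log units; beyond the scatter) as a large step, so this group is not interchangeable with its simpler partner in this series, a point the earlier pair could not settle. For the compounds shown here, the second new step, a 1.8-fold higher number from compound 1 to compound 3 (0.25 log units; within the scatter) and no order between the two, leaves 3-amino-4-methoxyphenyl as the only one of the three groups on this carbon whose number stands apart from the others, and compound 2 remains the lowest, beyond the scatter of both. Nothing at hand gives a measured reason for the size of the step from compound 2.

The exchange removes the methoxy group and alters the placing of the amino group in one move, so the step cannot be assigned to either change alone. The compounds shown leave open how a methoxyphenyl group carrying no amino group, or a hydroxyl group in place of the amino group, would read on this carbon.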